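Vinyl in place of isopropyl: notes on a small series

The source may report more compounds than this note shows. Statements on the series, on what has been measured and on what is new or still open speak of the compounds shown alone.

Compound 1 `CC(C)[N+](C)(C)CCCC(=O)[O-]` gives 5700 nM in an assay for inhibition of gamma-butyrobetaine dioxygenase (Homo sapiens), read by HPLC, with stated times of 15 min and 30 min; a higher number here means a weaker inhibitor, a lower number a stronger inhibitor.
Compound 2 `C=C[N+](C)(C)CCCC(=O)[O-]` gives 127000 nM in this assay.
Compound 3 `CC(C)[N+](C)(C)NCCC(=O)[O-]` gives only a limit of the assay, > 1000000 nM, in this assay.

The change vinyl in place of isopropyl on an amine nitrogen brought a 22-fold higher number from compound 1 to compound 2 (1.35 log units; beyond the scatter). Compound 4 `C=C[N+](C)(C)NCCC(=O)[O-]` carries the same kind of change from compound 3, (vinyl in place of isopropyl on an amine nitrogen); the place differs in that the amine nitrogen of compound 3 has an amine nitrogen among its other neighbours, where compound 1 has three saturated chain carbons. The difference between the two cores is not broken down here. Compound 3 sits at the limit of > 1000000 nM in this assay, at which 1 of the 3 values shown sits. Compound 4 is expected to give 3000000 nM, most likely again only a limit, resting on compound 3 already standing at the limit and on the weakening seen in a 22-fold higher number from compound 1 to compound 2 (1.35 log units; beyond the scatter). The expected step for compound 4 is a step that the limit leaves unreadable from compound 3 to compound 4.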

Compound 4, half-maximal inhibitory concentration: 6800 nM
For compound 4 the middle estimate is 440-fold (2.64 log units) above the measured one; measured number below the stated range.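

Vinyl in place of isopropyl on an amine nitrogen brought an at least 140-fold lower number from compound 3 to compound 4 (2.16 log units; beyond the scatter), and on the two cores the change runs in opposite directions: the same change on two cores in this assay, a 22-fold higher number (1.35 log units; beyond the scatter) from compound 1 to compound 2 and an at least 140-fold lower number (2.16 log units; beyond the scatter) from compound 3 to compound 4, at least 3200-fold (3.51 log units) apart, beyond the scatter of two such steps
Neither the direction nor the size of this change carries from one core to the other in this pair of cores, but one step per core does not show which difference between the cores goes with the reversal.
The value of compound 3, > 1000000 nM, is a limit of the assay and not a number.

Open, from the compounds shown here alone, is whether the reversal goes with the amine nitrogen among the neighbours in compound 3, which a core with an ether oxygen in its place would test. Also open, going by these compounds, is whether it holds for other groups on that nitrogen, such as ethyl or cyclopropyl.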